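Two aryl variations on a shared core, one still unmeasured

The source may hold more compounds than are shown below. What is called first, only, known or untested is meant among the compounds shown, and "the series" means these compounds.

Compound 1: `Cc1ccc(C2C(C#N)=C(N)N(c3ccc(S(N)(=O)=O)cc3)C3=C2C(=O)CCC3)cc1` — 30%
Compound 2: `N#CC1=C(N)N(c2ccc(S(N)(=O)=O)cc2)C2=C(C(=O)CCC2)C1c1ccc(Cl)cc1Cl` — 50%

In a functional assay on Ehrlich cells (Mus musculus) for antiproliferative activity, read by trypan blue exclusion, with a stated time of 2 h, tested at 25 ug/mL (a lower number here means a weaker effect, a higher number a stronger effect of the compound at the concentration tested), compound 2 gives 50%, the highest of the two numbers, with compound 1 as its nearest neighbour at 30%. Going by the values given here, the single measured step, a number 20 percentage points higher from compound 1 to compound 2 (beyond the scatter), concerns the same saturated ring carbon that the new change touches, and it is modest in size. Compound 3, `COc1ccc(C2C(C#N)=C(N)N(c3ccc(S(N)(=O)=O)cc3)C3=C2C(=O)CCC3)c2ccccc12`, has not yet been measured in this assay. It differs from compound 2 as follows: 4-methoxynaphthalen-1-yl in place of 2,4-dichlorophenyl on a saturated ring carbon. Among the compounds with values here, no measured pair shows what a 4-methoxynaphthalen-1-yl group does at this place, so the only guide is that swapping aryl groups on this carbon moved the number by a modest amount once, as seen in a number 20 percentage points higher from compound 1 to compound 2 (beyond the scatter). A step of comparable size in either direction, or none beyond the scatter, is therefore a reasonable expectation for a number 10 percentage points lower from compound 2 to compound 3 (within the scatter). On that basis compound 3 is estimated at 40% in this assay, with a plausible range from 20% to 65%.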

Compound 3, a percentage reported as activity, at one concentration (the size of the read-out at that concentration, not a potency): 10%
Compound 3: the middle estimate sits 30 percentage points above what was measured; measured number outside the range, below it.
By their numbers in this assay, from the lowest: compound 3; then compound 1; then compound 2.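

The saturated ring carbon that carries the aryl group can lower the read-out in this assay as well as raise it: the change to 4-methoxynaphthalen-1-yl gives a number 40 percentage points lower from compound 2 to compound 3 (beyond the scatter) and is the largest step among the three compounds, while the same group set against 4-methylphenyl gives a number 20 percentage points lower from compound 1 to compound 3 (beyond the scatter) on the shared core. Going by these compounds alone, the only earlier step at this carbon was a gain, so the aryl group alone now accounts for the whole spread of values, with compound 3 lowest and compound 2 highest. Nothing available explains the loss seen with the 4-methoxynaphthalen-1-yl group.

This change replaces one aromatic ring with two, removes both chlorines and adds a methoxy group all at once, so the three compounds cannot show which of these alterations matters. An unsubstituted naphthalen-1-yl group would separate the second ring from the methoxy group, and a 4-chlorophenyl or 4-methoxyphenyl group would show how a single substituent on one ring behaves at this carbon.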